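A few compounds are considered here, and "the series" means these few. Any claim that something is new, unique, unknown or untested is made for them only; others in the source may bear on it.

Measured so far:
compound 1 `CC1CCC(C(=O)N2CC(c3nc(-c4cccc(Cl)c4)no3)C2)CC1` — in an assay on HEK293 cells for negative allosteric modulation of metabotropic glutamate receptor 5 (Homo sapiens), read by FLIPR (on this read-out lower numbers stand for stronger inhibition and higher numbers for weaker inhibition), compound 1 gives only a limit, > 10000 nM.
compound 2 `O=C(N1CCCCC1)N1CC(c2nc(-c3cccc(Cl)c3)no2)C1` — in this assay compound 2 likewise gives only a limit, > 10000 nM.
compound 3 `O=C(c1ccccc1F)N1CC(c2nc(-c3cccc(Cl)c3)no2)C1` — in this assay compound 3 gives 670 nM.

Within the data shown here, compound 3 thus holds the only number in the set; the two other values sit at a limit (the limit of > 10000 nM in this assay, at which 2 of the 3 values shown sit). Compound 4 `CC1CCN(C(=O)N2CC(c3nc(-c4cccc(Cl)c4)no3)C2)CC1` is not yet measured and differs from compound 3 by 4-methylpiperidin-1-yl in place of 2-fluorophenyl on a carbonyl carbon. Among the measured compounds shown here, the steps that bear on this are an at least 14-fold lower number from compound 1 to compound 3 (1.17 log units; beyond the scatter) and an at least 14-fold lower number from compound 2 to compound 3 (1.17 log units; beyond the scatter), both running from a non-aromatic carbonyl substituent to the 2-fluorophenyl; compound 4 runs the other way, towards a 4-methylpiperidin-1-yl. The step that the two limits leave unreadable from compound 1 to compound 2 between two limits gives no further reading. A large weakening is therefore expected, a 22-fold higher number from compound 3 to compound 4 (1.35 log units; beyond the scatter). Compound 4 is estimated at 15000 nM, range 3000 nM to 60000 nM, most likely reported only as a limit.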

Compound 4, half-maximal inhibitory concentration: > 10000 nM
Compound 4: a limit, no number; the forecaster's own chance of this, stated with the estimate: 75%; the middle value is on the limit's open side.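

In this assay, among these compounds, 4-methylpiperidin-1-yl in place of 2-fluorophenyl on a carbonyl carbon gives an at least 14-fold higher number from compound 3 to compound 4 (1.17 log units; beyond the scatter) and leaves the 2-fluorophenyl of compound 3 as the only group at this position with a number, with no compound of the four going against this. Compound 4 gives > 10000 nM as a limit only. The steps from compound 1 and from compound 2 to compound 4 cannot be read, so the added methyl shows nothing here: the limit of > 10000 nM in this assay, at which 3 of the 4 values shown sit.

Still open, as far as these compounds go, is whether the aromatic ring alone is enough or the fluorine is also needed. A plain phenyl or a 2-methoxyphenyl on the same carbonyl carbon would separate the two.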